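Three Limits and a Swapped Aromatic Group

A few compounds are considered here, and "the series" means these few. Any claim that something is new, unique, unknown or untested is made for them only; others in the source may bear on it.

In a functional assay on ECV-304 cells (Homo sapiens) for cytotoxicity (a higher number here means a weaker inhibitor, a lower number a stronger inhibitor), compound 3 (`N#Cc1ccc(/C=C2\SC(=S)N(NS(=O)(=O)c3ccccc3)C2=O)cc1`) gives > 50000 nM as its reading, and this is a limit of the assay, not a number. Compound 1 (`Cc1ccc(S(=O)(=O)NN2C(=S)S/C(=C\c3ccc(Cl)c(Cl)c3)C2O)cc1`) gives > 50000 nM as a limit too. Compound 2 (`O=S(=O)(NN1C(=S)S/C(=C\c2ccc(Cl)c(Cl)c2)C1O)c1ccc(Cl)cc1`) gives > 50000 nM as a limit as well. Among the measured compounds shown here, the series so far therefore stands at the limit of > 50000 nM in this assay, at which 3 of the 3 values shown sit, and compound 3 has no exact place among its relatives.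

Compound 4 (`O=C1/C(=C/c2cc(F)c(F)cc2F)SC(=S)N1NS(=O)(=O)c1ccccc1`) differs from compound 3 at one place, where 4-cyanophenyl leaves and 2,4,5-trifluorophenyl enters (2,4,5-trifluorophenyl in place of 4-cyanophenyl on a double-bonded chain carbon bound to a double-bonded ring carbon). For the measured compounds named here, the only step measured so far is a step that the two limits leave unreadable from compound 1 to compound 2 and it offers no size to carry over to this change. With no readable step to build on, no shift beyond the usual scatter is expected in this assay and no direction is favoured. The estimated outcome is a number no higher from compound 3 to compound 4 (the limit leaves the size open). This expectation rests on (the limit of > 50000 nM in this assay, at which 3 of the 3 values shown sit). Compound 4 is expected at about 50000 nM in an estimated range from 25000 nM to 100000 nM. It may well give only a limit again.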

Compound 4, half-maximal inhibitory concentration: > 50000 nM
Compound 4: only a limit was reported (the forecaster's own chance of this, stated with the estimate: 80%); the middle value sits exactly at the limit.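

On these data alone, compound 3 and compound 4 both stand at a limit rather than a number in this assay, so the step between them cannot be read, and the size of the change from 4-cyanophenyl to 2,4,5-trifluorophenyl stays unknown. The compounds shown leave open how any of them ranks against the others, because all share one limit: the limit of > 50000 nM in this assay, at which 4 of the 4 values shown sit.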